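Replacing benzyl by 2-fluorophenyl on the ring nitrogen

A few compounds are considered here, and "the series" means these few. Any claim that something is new, unique, unknown or untested is made for them only; others in the source may bear on it.

Compound 1 `O=c1nc2oc(C3CC3)c(C#CC3CC3)c2cn1Cc1cn(Cc2ccccc2)nn1` is the reference point of this note. For the measured compounds named here, in an ADME assay on WI-38 cells (Homo sapiens) for antiproliferative activity, read by MTT assay, with a stated time of 72 h (a lower number here means a stronger inhibitor, a higher number a weaker inhibitor), compound 1 gives 290 nM, the only numerical value so far in the set. Compound 2 `O=c1nc2oc(CCCCl)cc2cn1Cc1cn(-c2ccc(F)cc2)nn1` carries a 4-fluorophenyl directly on the aromatic nitrogen and a chlorobutyl chain on the core. In this assay compound 2 reaches < 10 nM, which is a limit of the assay and not a number: the limit of < 10 nM in this assay, at which 1 of the 2 values shown sits. Going by the values given here, compound 2 differs from compound 1 in more than one place, so no single step between them is counted; the two values show only that compound 2 sits at the limit while compound 1 stands well away from it.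

Compound 3 `O=c1nc2oc(C3CC3)c(C#CC3CC3)c2cn1Cc1cn(-c2ccccc2F)nn1` keeps the core of compound 1 and changes a single group: 2-fluorophenyl in place of benzyl on an aromatic nitrogen. An aryl group attached straight to the aromatic nitrogen is the feature compound 3 shares with compound 2. On that basis a step toward stronger inhibition in this assay is expected from compound 1 to compound 3, a 4.8-fold lower number from compound 1 to compound 3 (0.68 log units; beyond the scatter), beyond the scatter but short of the limit. Compound 3 is estimated at 60 nM, with a range from 15 nM to 250 nM.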

Compound 3, half-maximal inhibitory concentration: 45900 nM
For compound 3 the middle estimate is 770-fold (2.88 log units) below the measured one, and the stated range ends below it.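

On the core of compound 1, the aromatic nitrogen of the five-membered aromatic ring with 3 nitrogen proves a sensitive place: in this assay, 2-fluorophenyl in place of benzyl gives a 160-fold higher number from compound 1 to compound 3 (2.20 log units; beyond the scatter). The counts do not distinguish the two groups in most respects: each has 7 heavy atoms and one six-membered aromatic ring of carbon only, with 0 hydrogen-bond donors, 0 hydrogen-bond acceptors and no net charge, so a large step can accompany a swap that leaves all of these unchanged. No measurement at hand gives a cause for this step.

This single pair changes two things at once, the loss of the carbon link to the ring and the arrival of fluorine, and a plain phenyl or a 2-fluorobenzyl on the same nitrogen of the core of compound 1 would be needed to separate them. From the compounds shown here alone, whether a step of this size also appears on other cores, or with a longer chain between the nitrogen and the aromatic ring, remains open.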